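Piperazine amide: trifluoroacetyl to formyl in the series

The compounds below may be only part of what the source reports. "The series", "measured", "known", "first", "only" and "open" are said of these compounds alone.

Compound 2 `Cc1cc(C#N)cc(C)c1Oc1nc(Nc2ccc(C#N)cc2)ncc1/C=C/C(=O)N1CCN(C(=O)C(F)(F)F)CC1` in an ADME assay on TZM cells (Homo sapiens) for cytotoxicity, with a stated time of 1 days (a higher number here means that more compound is tolerated, a lower number that less compound is tolerated), gives only a limit, > 174 nM. Compound 1 `Cc1cc(C#N)cc(C)c1Oc1nc(Nc2ccc(C#N)cc2)ncc1/C=C/C(N)=O` in this assay also gives only a limit, > 243 nM. The step that the two limits leave unreadable from compound 1 to compound 2 is therefore not readable. Compound 3 `Cc1cc(C#N)cc(C)c1Oc1nc(Nc2ccc(C#N)cc2)ncc1/C=C/C(=O)N1CCN(C=O)CC1` differs from compound 2 by hydrogen in place of trifluoromethyl on a carbonyl carbon. Both measured values stand at limits, the limit of > 174 nM in this assay, at which 1 of the 2 values shown sits, and (the limit of > 243 nM in this assay, at which 1 of the 2 values shown sits), so no readable step bears on this change, and no step beyond the scatter in this assay is expected. Compound 3 is expected at 200 nM, with a range from 100 nM to 400 nM. The expected step is a step that the limit leaves unreadable from compound 2 to compound 3.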

Compound 3, half-maximal cytotoxic concentration: > 197 nM
Compound 3 ended at the assay's limit; the forecaster's own chance of this, stated with the estimate: 85%; the middle value is on the limit's open side.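

Going by these compounds alone, compound 1, compound 2 and compound 3 all give only limits in this assay, so no step among them can be read. The compounds shown leave open where any of their half-maximal cytotoxic concentrations actually lies.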